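Bromo in Place of Hydroxy on the Aryl Ether

This account rests on a few compounds, and the source may have more. Where it says the series, first, only, none or still open, it means among the compounds named here.

Compound 1 `CSc1ccc(OC(C)(C)C2OCC(C/C=C\CCC(=O)O)C(c3cccnc3)O2)c([N+](=O)[O-])c1`: 22 nM in an assay for inhibition of Thromboxane-A synthase (Homo sapiens), using microsomes; a higher number here means a weaker inhibitor, a lower number a stronger inhibitor
Compound 2 `COc1ccccc1OC(C)(C)C1OCC(C/C=C\CCC(=O)O)C(c2cccnc2)O1`: 60 nM
Compound 3 `CC(C)(Oc1ccccc1O)C1OCC(C/C=C\CCC(=O)O)C(c2cccnc2)O1`: 32 nM

Compound 3 gives the second highest of the three numbers, yet both of its neighbours sit within the scatter: a 1.5-fold higher number from compound 1 to compound 3 (0.16 log units; within the scatter) and a 1.9-fold lower number from compound 2 to compound 3 (0.27 log units; within the scatter). Compound 4 `CC(C)(Oc1ccccc1Br)C1OCC(C/C=C\CCC(=O)O)C(c2cccnc2)O1` differs from compound 3 in one place: bromo in place of hydroxy on an aromatic carbon. Within the data shown here, no measured step exchanges a hydroxy for a halogen, so the bearing of the known steps is indirect. Changes at this ring so far have been small: a 1.9-fold lower number from compound 2 to compound 3 (0.27 log units; within the scatter) and a 1.5-fold higher number from compound 1 to compound 3 (0.16 log units; within the scatter) stayed within the scatter, while only a 2.7-fold higher number from compound 1 to compound 2 (0.44 log units; beyond the scatter) went beyond it. A step of similar modest size, in either direction or none, is therefore expected for compound 4, a 1.1-fold lower number from compound 3 to compound 4 (0.03 log units; within the scatter). The estimate for compound 4 in this assay is 30 nM, expected between 12 nM and 80 nM.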

Compound 4, half-maximal inhibitory concentration: 29 nM
Beside the measured number, compound 4's estimate is 1.0-fold (0.01 log units) above it; low and high end bracket the measured number.
By their numbers in this assay, from the lowest: compounds 1, 4, 3 and 2 (each within the scatter of the next, the first and the last beyond it).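

In this assay, hydroxy and bromo at this aromatic carbon stay within the scatter of each other (a 1.1-fold lower number from compound 3 to compound 4 (0.04 log units; within the scatter)), although hydroxy counts one hydrogen-bond donor and one acceptor and bromo counts neither. Bromo in place of methoxy is a modest step (a 2.1-fold lower number from compound 2 to compound 4 (0.32 log units; beyond the scatter)), while the differently substituted aryl group of compound 1 stays within the scatter (a 1.3-fold higher number from compound 1 to compound 4 (0.12 log units; within the scatter)). No measurement shown here explains these results.

From the compounds shown here alone, whether chloro, an amine or a carboxylic acid at this same carbon would give a similar number remains open. So does whether bromo would fare alike elsewhere on this ring.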